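A few compounds are considered here, and "the series" means these few. Any claim that something is new, unique, unknown or untested is made for them only; others in the source may bear on it.

Compounds measured so far:
compound 1, `COc1ccc(/C=C\c2cc(OC)c(OC)c(OC)c2)cc1OCc1ccc(CN[C@H](C(=O)O)[C@@H](C)O)cc1`: > 10000 nM
compound 2, `COc1ccc(/C=C\c2cc(OC)c(OC)c(OC)c2)cc1OCc1ccc(CNCCO)cc1`: 4400 nM

In a functional assay on HeLa cells (Homo sapiens) for antiproliferative activity, read by CCK-8 assay, with a stated time of 48 h (a higher number here means a weaker inhibitor, a lower number a stronger inhibitor), compound 1 gives only a limit, > 10000 nM, not a number. For the measured compounds named here, compound 2 in this assay gives 4400 nM, the single numeric value in the set so far, so it stands as the one fixed point against which the next compound is read. Going by the values given here, the step of an at least 2.2-fold lower number from compound 1 to compound 2 (0.35 log units; beyond the scatter) is the only measured step; its size is bounded by the limit of > 10000 nM in this assay, at which 1 of the 2 values shown sits, so only a lower bound on that gain is known.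

Compound 3, `COc1ccc(/C=C\c2cc(OC)c(OC)c(OC)c2)cc1OCc1ccc(CNC(C)(C)C(=O)O)cc1`, is not yet measured. It differs from compound 2 by 1-carboxy-1-methylethyl in place of 2-hydroxyethyl on an amine nitrogen. The measured step bears on this change: the move from compound 1 to compound 2 replaced 1-carboxy-2-hydroxypropyl with 2-hydroxyethyl, and compound 3 brings a carboxy-bearing group, 1-carboxy-1-methylethyl, back onto the amine nitrogen. On that basis the expected direction in this assay is towards a higher number, and the step of a 2.0-fold higher number from compound 2 to compound 3 (0.31 log units; beyond the scatter) is expected, with a real chance that compound 3 returns to the limit. Compound 3 is therefore estimated at 9000 nM, with a range from 3500 nM to 25000 nM.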

Compound 3, half-maximal inhibitory concentration: > 10000 nM
Compound 3: no number, only a limit; the forecaster's own chance of this, stated with the estimate: 45%; middle value at least 1.1-fold (0.04 log units) from the limit.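

In this assay compound 3 gives > 10000 nM, which is a limit and not a number. Set on the amine nitrogen in place of 2-hydroxyethyl, 1-carboxy-1-methylethyl gives an at least 2.2-fold higher number from compound 2 to compound 3 (0.35 log units; beyond the scatter), so the loss is not tied to the 1-carboxy-2-hydroxypropyl group of compound 1: both carboxy-bearing groups shown give a weaker compound than compound 2, and no compound shown goes against this, though three compounds make a narrow base. The step between compound 1 and compound 3 cannot be read, and the two carboxy-bearing groups cannot be ordered against each other: the limit of > 10000 nM in this assay, at which 2 of the 3 values shown sit.

The compounds shown do not separate the carboxylic acid itself from the extra carbons that come with it in each carboxy-bearing group, and a methyl ester or a primary amide in its place would speak to that. Also open, going by these compounds, is how the amine nitrogen responds to a 3-hydroxypropyl chain or a 2-aminoethyl group, and whether anything there gives a lower number than compound 2 at 4400 nM.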